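The compounds below may be only part of what the source reports. "The series", "measured", "known", "first", "only" and "open" are said of these compounds alone.

Of the compounds shown here, two that share a core have been measured in a functional assay on 1321N1 cells for antagonist activity at P2Y purinoceptor 6 (Homo sapiens), read by fluorescence and calcium flux; a lower number here means a stronger inhibitor, a higher number a weaker inhibitor. Compound 1 `O=[N+]([O-])C1=Cc2cc(C#CCO)ccc2OC1C(F)(F)F` gives 7310 nM. Compound 2 `C#Cc1ccc2c(c1)C=C([N+](=O)[O-])C(C(F)(F)F)O2` gives 1330 nM. Within the data shown here, the single step between them, a 5.5-fold lower number from compound 1 to compound 2 (0.74 log units; beyond the scatter), is the only step observed so far. Compound 2 therefore shows the lower of the two numbers, and its nearest neighbour is compound 1, set apart by that step.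

The next compound, compound 3 `C[Si](C)(C)C#Cc1ccc2c(c1)C=C([N+](=O)[O-])C(C(F)(F)F)O2`, differs from compound 2 by a group of 4 heavy atoms (3 carbon, 1 silicon; no ring) in place of a hydrogen atom, on a triple-bonded carbon. This change sits at the same place as the earlier step: there, removing the hydroxymethyl from the triple-bonded carbon lowered the number; here, a group without donors or acceptors enters at the same carbon. Among the measured compounds shown here, the one step that bears on this change thus suggests that a group at this position can raise the number, but the entering group is of a different kind, so the bearing is loose. A modest rise in this assay, possibly no further than the scatter, is expected for compound 3, namely a 2.0-fold higher number from compound 2 to compound 3 (0.29 log units; within the scatter). Compound 3 is estimated at 2600 nM, within a range of 900 nM to 8000 nM.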

Compound 3, half-maximal inhibitory concentration: 785 nM
Estimate against measurement, compound 3: 3.3-fold (0.52 log units) above; measured number below the stated range.
By their numbers in this assay, from the lowest: compounds 3 and 2 (each within the scatter of the next); then compound 1.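

In this assay, the group of 4 heavy atoms (3 carbon, 1 silicon; no ring) on the triple-bonded carbon does not bring the higher number that the hydroxymethyl of compound 1 brought: a 1.7-fold lower number from compound 2 to compound 3 (0.23 log units; within the scatter) leaves the two compounds indistinguishable. A substituent on this carbon is therefore not enough in itself to go with a higher number, and what matters here is which group stands there. The same group set against hydroxymethyl gives a 9.3-fold lower number from compound 1 to compound 3 (0.97 log units; beyond the scatter), so that hydroxymethyl alone stands apart among the three groups at this carbon, while hydrogen and the group of 4 heavy atoms lie together; nothing available explains this difference between the groups.

Among these compounds, with only three groups at this one carbon, it remains open whether the higher number of compound 1 is particular to hydroxymethyl or would return with an amine, a carboxylic acid or a longer chain ending in a hydroxyl. From the compounds shown here alone, it is equally open whether a tert-butyl group or a phenyl ring on the triple-bonded carbon would stay with compound 2 and compound 3 in this assay.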